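The source may hold more compounds than are shown below. What is called first, only, known or untested is meant among the compounds shown, and "the series" means these compounds.

Working notes on the series. The measurement throughout is an ADME assay on MDCK cells (Canis lupus familiaris) for cytotoxicity, read by microscopy, with a stated time of 48 h; a lower number here means that less compound is tolerated, a higher number that more compound is tolerated. Compound 1, `CCc1csc(CN[C@@H]2C[C@H]3C[C@@H]([C@H]2C)C3(C)C)c1`, gives 25000 nM in this assay. Compound 2, `CCc1ccc(CN[C@@H]2C[C@H]3C[C@@H]([C@H]2C)C3(C)C)s1`, gives 1560 nM in this assay. Compound 3, `C[C@H]1[C@H](NCc2cncnc2)C[C@H]2C[C@@H]1C2(C)C`, is reported in this assay only as a limit, > 100000 nM, so no number exists for it. That limit is the point at which one of the three recorded values sits, (the limit of > 100000 nM in this assay, at which 1 of the 3 values shown sits). Compound 1 and compound 2 both sit at numbers rather than at a limit, so on the numbers shown compound 3 stands at the tolerated end of the set.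

Compound 4, `C[C@H]1[C@H](NCc2ccoc2)C[C@H]2C[C@@H]1C2(C)C`, is not yet measured in this assay. Relative to compound 3 the change is furan-3-yl in place of pyrimidin-5-yl on a saturated chain carbon bound to an amine nitrogen. Among the measured compounds shown here, no measured pair differs in exactly one place, so the size of this step has no direct precedent in the set. With compound 1 and compound 2 both giving numbers, and compound 3 only a limit, the expectation for compound 4 is a step from compound 3 toward a measurable number, with a fair chance that the assay again reports only a limit. The step expected is an at least 2.0-fold lower number from compound 3 to compound 4 (0.30 log units; that floor lies within the scatter). Compound 4 is estimated at 50000 nM, within a range of 12000 nM to 100000 nM.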

Compound 4, minimum cytotoxic concentration: > 100000 nM
Compound 4: only a limit was reported (the forecaster's own chance of this, stated with the estimate: 40%); middle value at least 2.0-fold (0.30 log units) away from the limit.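

Compound 3 and compound 4 are both reported only as limits in this assay, so no step can be read between them: the limit of > 100000 nM in this assay, at which 2 of the 4 values shown sit.

The compounds shown leave open whether furan-3-yl in place of pyrimidin-5-yl changes the minimum cytotoxic concentration at all.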